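Chloro Added to a Weakly Antiproliferative Scaffold

A few compounds are considered here, and "the series" means these few. Any claim that something is new, unique, unknown or untested is made for them only; others in the source may bear on it.

Compound 1 `N#Cc1c(-c2ccccc2)nc2c(c(-c3ccccc3)nn2-c2ccccc2)c1-c1ccc(O)cc1` — 33400 nM
Compound 2 `COc1ccc(-c2c(C#N)c(-c3ccccc3)nc3c2c(-c2ccccc2)nn3-c2ccccc2)cc1OC` — > 25000 nM

Of the compounds shown here, two that share one core have been measured. Among the measured compounds shown here, in a functional assay on CCRF-CEM cells (Homo sapiens) for antiproliferative activity, read by resazurin assay, with a stated time of 72 h (a higher number here means a weaker inhibitor, a lower number a stronger inhibitor), compound 1 gives 33400 nM, and this is the only number among the two values shown. The value of compound 2 is a limit of the assay and not a number. The step that the limit leaves unreadable from compound 1 to compound 2, which swaps in a 3,4-dimethoxyphenyl in place of 4-hydroxyphenyl on an aromatic carbon, cannot be sized because of the limit of > 25000 nM in this assay, at which 1 of the 2 values shown sits.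

Compound 3 `N#Cc1c(-c2ccc(Cl)cc2)nc2c(c(-c3ccccc3)nn2-c2ccccc2)c1-c1ccc(O)cc1` has not yet been measured. It differs from compound 1 by chloro in place of hydrogen on an aromatic carbon. For the measured compounds named here, no measured step touches this part of the molecule: the only step recorded concerns the 4-hydroxyphenyl group, and it is unreadable in any case. There is thus nothing to suggest a move beyond the scatter in either direction, and the expected step of a 1.0-fold lower number from compound 1 to compound 3 (0.01 log units; within the scatter) is small. Compound 3 is therefore estimated to give 33000 nM in this assay, with a range from 12000 nM to 90000 nM.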

Compound 3, half-maximal inhibitory concentration: 43100 nM
Estimate against measurement, compound 3: 1.3-fold (0.12 log units) below; measured number inside the range.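

Chloro in place of hydrogen at this position gives the first readable step among these compounds. In this assay, the change from phenyl to 4-chlorophenyl gives a 1.3-fold higher number from compound 1 to compound 3 (0.11 log units; within the scatter), so this single chlorine atom, on a six-membered aromatic ring of carbon only and para to a large group, makes no difference that can be told apart from the ordinary spread of repeated measurements. Among the compounds shown here, since the earlier step concerned only the 4-hydroxyphenyl group, this is also the first reading at this part of the molecule, and it shows that this one substitution leaves the scaffold in the same weak range of antiproliferative activity.

On these data alone, the value of compound 2 is a limit and not a number, so its step from compound 1 still cannot be read, and it is not known how far changes to the 4-hydroxyphenyl group can move activity: the limit of > 25000 nM in this assay, at which 1 of the 3 values shown sits. One small atom at one position also says little about the position as a whole, so it remains open whether an amine, a carboxylic acid or a longer chain in place of the chloro would give a step beyond the scatter.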